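The source may hold more compounds than are shown below. What is called first, only, known or untested is meant among the compounds shown, and "the series" means these compounds.

Measured so far in an ADME assay on Huh-7 cells (Homo sapiens) for cytotoxicity; on this read-out lower numbers stand for stronger inhibition of growth and higher numbers for weaker inhibition of growth:
- compound 1 `COc1cc2c(=O)c(C(=O)c3ccc(C)cc3)cn(CC3CCCCC3)c2cc1OC`: 22000 nM
- compound 2 `COc1cc2c(=O)c(C(=O)c3ccc(C)cc3)cn(CCCc3ccccc3)c2cc1OC`: "not active" (no number reported)
- compound 3 `COc1cc2c(=O)c(C(=O)c3ccc(C)cc3)cn(Cc3ccc(C(C)C)cc3)c2cc1OC`: 15500 nM

Among the measured compounds shown here, compound 2 is reported only as inactive, without a number, so only two numbers stand in this assay. For the measured compounds named here, compound 1 and compound 3 lie within the scatter of one another: the step of a 1.4-fold lower number from compound 1 to compound 3 (0.15 log units; within the scatter) is small, and it is the only step measured at a single point of change. It shows that swapping the saturated ring on the chain carbon bound to the aromatic nitrogen for an aromatic ring carrying an alkyl group moves this assay little, if at all. Going by the values given here, the inactive compound 2, which carries a longer chain at the same nitrogen, hints that changes at this position can also lose activity, but no step to it can be sized.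

Compound 4 `COc1cc2c(=O)c(C(=O)c3ccc(C)cc3)cn(Cc3ccc(S(C)(=O)=O)cc3)c2cc1OC` differs from compound 1 in one place: 4-(methylsulfonyl)phenyl in place of cyclohexyl on a saturated chain carbon bound to an aromatic nitrogen. Among the compounds with values here, the measured step from compound 1 to compound 3 bears on it only in part, since a ring-for-ring swap at this position was tolerated; the methylsulfonyl group itself has no precedent in the set. The expected step of a 1.1-fold higher number from compound 1 to compound 4 (0.06 log units; within the scatter) is therefore small, with no clear direction beyond the scatter. For compound 4 the estimate in this assay is 25000 nM, expected to fall between 8000 nM and 80000 nM.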

Compound 4, concentration for 50% growth inhibition: > 50000 nM
Compound 4: no number, only a limit; the forecaster's own chance of this, stated with the estimate: 35%; middle value at least 2.0-fold (0.30 log units) from the limit.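

In this assay this position proves not to be indifferent to what the ring carries: the step of an at least 2.2-fold higher number from compound 1 to compound 4 (0.35 log units; beyond the scatter) lies beyond the scatter, whereas the earlier swap to 4-isopropylphenyl stayed within it. With the aromatic ring kept and only its substituent exchanged, the step of an at least 3.2-fold higher number from compound 3 to compound 4 (0.50 log units; beyond the scatter) also lies beyond the scatter, so among these compounds the shift in the read-out follows the methylsulfonyl group and not the exchange of a saturated ring for an aromatic one. The entry for compound 4 is a limit and not a number, so both steps give only a lower bound on their size: the limit of > 50000 nM in this assay, at which 1 of the 4 values shown sits.

From the compounds shown here alone, it remains open whether this shift is particular to methylsulfonyl or would also appear with a carboxylic acid, an amine or a methoxy group at the same place on the ring. Also open, going by these compounds, are how far compound 4 lies past its limit and whether a longer chain between the aromatic nitrogen and the 4-(methylsulfonyl)phenyl ring would change the read-out.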